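Sulfur substituent swap in an antiproliferative series

This account rests on a few compounds, and the source may have more. Where it says the series, first, only, none or still open, it means among the compounds named here.

Compound 1 `CN1CCN(c2ccc(Nc3ncc4nc(Sc5ccccc5)n(C5CCOCC5)c4n3)cc2)CC1` and compound 2 `CN1CCN(c2ccc(Nc3ncc4nc(SCc5cccnc5)n(C5CCOCC5)c4n3)cc2)CC1` share one core and differ only at the sulfur. In a functional assay on HCC827 cells (Homo sapiens) for antiproliferative activity, read by MTT assay, with a stated time of 72 h (a higher number here means a weaker inhibitor, a lower number a stronger inhibitor), compound 1 gives 42.6 nM, while compound 2 gives 500 nM. The change between them, (phenyl in place of (pyridin-3-yl)methyl on a sulfur), produced a 12-fold lower number from compound 2 to compound 1 (1.07 log units; beyond the scatter).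

Compound 3 `CN1CCN(c2ccc(Nc3ncc4nc([S+]([O-])Cc5cccnc5)n(C5CCCC5)c4n3)cc2)CC1` is built on a different core; in this assay compound 3 gives 2350 nM, the highest number among the three measured compounds. The difference between the core of compound 3 and the core of compound 2 is not broken down here.

Compound 4 `CN1CCN(c2ccc(Nc3ncc4nc([S+]([O-])c5ccccc5)n(C5CCCC5)c4n3)cc2)CC1` has not yet been measured. It differs from compound 3 by phenyl in place of (pyridin-3-yl)methyl on a sulfur. Within the data shown here, this is the same kind of change as the one from compound 2 to compound 1, but not the same: in compound 3 and compound 4 the sulfur carries an oxygen neighbour besides the aromatic carbon, whereas in compound 1 and compound 2 the sulfur has only the aromatic carbon as its other neighbour.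

For compound 4 in this assay a step of a 7.8-fold lower number from compound 3 to compound 4 (0.89 log units; beyond the scatter) is expected, somewhat smaller than the measured one, because a 12-fold lower number from compound 2 to compound 1 (1.07 log units; beyond the scatter) was obtained on a sulfur without the oxygen neighbour and on the other core. Compound 4 is therefore estimated at 300 nM, with a range from 100 nM to 900 nM.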

Compound 4, half-maximal inhibitory concentration: 64.7 nM
Estimate against measurement, compound 4: 4.6-fold (0.67 log units) above, outside the stated range (below it).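

In this assay, phenyl in place of (pyridin-3-yl)methyl on a sulfur gives a lower number in both matched pairs, and on the sulfur with an oxygen neighbour the result is a 36-fold lower number from compound 3 to compound 4 (1.56 log units; beyond the scatter). The direction of the change therefore carries from one core to the other, but its size does not transfer unchanged: the same change on two cores in this assay, a 12-fold lower number (1.07 log units; beyond the scatter) from compound 2 to compound 1 and a 36-fold lower number (1.56 log units; beyond the scatter) from compound 3 to compound 4, 3.1-fold (0.49 log units) apart, beyond the scatter of two such steps. The comparison does not show what sets the two step sizes apart, as the pairs differ both in the oxygen on the sulfur and elsewhere in the core, and two pairs cannot establish a general rule for the series.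

Going by these compounds, it remains open whether the lower numbers follow from removing the ring nitrogen, from removing the methylene link, or from both, which benzyl and pyridin-3-yl groups on the sulfur would help to separate. Also open, on these data alone, is what the oxygen on the sulfur contributes alone, which would take a single core carrying the same sulfur group with and without that oxygen, and whether a simple alkyl chain or an amine-bearing chain on the sulfur would follow the same trend.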